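A few compounds are considered here, and "the series" means these few. Any claim that something is new, unique, unknown or untested is made for them only; others in the source may bear on it.

Compound 1 `C/C(=N\NC(=O)c1cccc(S(=O)(=O)N2CCOCC2)c1)c1cccc(N)c1` gives in a functional assay on PC-3 cells (Homo sapiens) for antiproliferative activity, read by MTT assay, with a stated time of 72 h (on this read-out lower numbers stand for stronger inhibition and higher numbers for weaker inhibition), a value of > 100000 nM, which is a limit of the assay rather than a number.
Compound 2 `C/C(=N\NC(=O)c1cccc(S(=O)(=O)N2CCOCC2)c1)c1ccc(F)cc1` gives in this assay a value of 81300 nM.
Compound 3 `C/C(=N\NC(=O)c1cccc(S(=O)(=O)N2CCOCC2)c1)c1ccccc1O` gives in this assay a value of 2810 nM.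

All three compounds share one core and differ only in the aryl group on the carbon with a double bond to nitrogen. Compound 3 has the lowest of the two numbers measured in this assay; compound 2 is nearest, and the step between them, a 29-fold lower number from compound 2 to compound 3 (1.46 log units; beyond the scatter), is large. The step of an at least 35-fold lower number from compound 1 to compound 3 (1.55 log units; beyond the scatter) is likewise large, while an at least 1.2-fold lower number from compound 1 to compound 2 (0.08 log units; that floor lies within the scatter) stays within the scatter. For compound 1 this rests on (the limit of > 100000 nM in this assay, at which 1 of the 3 values shown sits).

Compound 4 `C/C(=N\NC(=O)c1cccc(S(=O)(=O)N2CCOCC2)c1)c1cccc(O)c1` has not yet been measured. It differs from compound 3 by 3-hydroxyphenyl in place of 2-hydroxyphenyl on a carbon with a double bond to nitrogen. For the measured compounds named here, no measured step moves a hydroxyl between ring positions, so the nearest guides are the steps into compound 3: both aryl groups without a 2-hydroxyphenyl gave much higher numbers than compound 3. Moving the hydroxyl away is therefore expected to cost potency, with a step of about a 7.1-fold higher number from compound 3 to compound 4 (0.85 log units; beyond the scatter) expected. Compound 4 is estimated at 20000 nM, in the range from 4000 nM to 100000 nM.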

Compound 4, half-maximal inhibitory concentration: > 100000 nM
Compound 4: no number, only a limit; the forecaster's own chance of this, stated with the estimate: 20%; middle value at least 5.0-fold (0.69 log units) away from the limit.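

Swapping 2-hydroxyphenyl for 3-hydroxyphenyl keeps the same atoms and joins them differently, yet it gives an at least 35-fold higher number from compound 3 to compound 4 (1.55 log units; beyond the scatter), so on this carbon with a double bond to nitrogen, having a hydroxyl on the aryl group is not enough to keep the activity of compound 3. The other readable step, an at least 1.2-fold higher number from compound 2 to compound 4 (0.08 log units; that floor lies within the scatter), is only a floor within the scatter, so 3-hydroxyphenyl cannot be ranked against 4-fluorophenyl, and 2-hydroxyphenyl remains the only aryl group shown that stands apart from the others beyond the scatter. The step for hydroxy in place of amino on an aromatic carbon cannot be read, since compound 1 and compound 4 both end at a limit rather than a number: the limit of > 100000 nM in this assay, at which 2 of the 4 values shown sit.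

Open, from the compounds shown here alone, is whether compound 3, at 2810 nM, would keep its activity if 2-methoxyphenyl or 2-aminophenyl replaced its 2-hydroxyphenyl. Also open are where 4-hydroxyphenyl would fall and what lies behind the large difference between the two hydroxyphenyl groups, for which the compounds shown offer no cause.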